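The source may hold more compounds than are shown below. What is called first, only, known or untested is meant among the compounds shown, and "the series" means these compounds.

In a functional assay on cells (Panel renal (Carcinoma cell lines), Homo sapiens) for antiproliferative activity (a lower number here means a stronger inhibitor of growth, a higher number a weaker inhibitor of growth), compound 1 `COc1cccc(-c2nn(-c3ccccc3)cc2-c2ccnc(NCCNC(=O)Nc3ccc(Cl)c(Cl)c3)c2)c1` gives 4630 nM and compound 2 `COc1cccc(-c2nn(-c3ccccc3)cc2-c2ccnc(NCCCNC(=O)Nc3ccc(Cl)c(Cl)c3)c2)c1` gives 3140 nM. Compound 3 `O=C(NCCCNc1cc(-c2cn(-c3ccccc3)nc2-c2cccc(O)c2)ccn1)c1ccccc1` gives 3630 nM in this assay, a number that lies within the usual scatter of both compound 1 and compound 2, so the three cannot be separated on these measurements. Compound 4 `O=C(NCCCNc1cc(-c2cn(-c3ccccc3)nc2-c2cccc(O)c2)ccn1)c1ccc(F)cc1` differs from compound 3 in one place: fluoro in place of hydrogen on an aromatic carbon. Among the measured compounds shown here, no pair of measured compounds shows what such a change does here. The step expected in this assay, a 1.1-fold lower number from compound 3 to compound 4 (0.05 log units; within the scatter), is no larger than the scatter and in no particular direction. Compound 4 is therefore estimated at 3200 nM in this assay, within a range from 1300 nM to 8000 nM.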

Compound 4, concentration for 50% growth inhibition: 2840 nM
For compound 4 the middle estimate is 1.1-fold (0.05 log units) above the measured one; the measured number falls inside the stated range.
By their numbers in this assay, from the lowest: compounds 4, 2, 3 and 1 (each within the scatter of the next).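

Going from phenyl to 4-fluorophenyl on the benzoyl group gives, in this assay, a 1.3-fold lower number from compound 3 to compound 4 (0.11 log units; within the scatter), so this carbon carries fluoro in place of hydrogen with no change that can be told from the scatter. No evidence is available that bears on this step. On these data alone, whether a methoxy group, a trifluoromethyl group or an amine on the same carbon would give a number beyond the scatter stays open. So does whether fluoro on another carbon of this ring would behave as it does here.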